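Swapping the Aryl Group on the Ring Nitrogen

The source may report more compounds than this note shows. Statements on the series, on what has been measured and on what is new or still open speak of the compounds shown alone.

Compound 2 `N#CC1=C(N)Oc2c(N)cc3nc4ccccc4nc3c2C12C(=O)N(Cc1cnnn1-c1ccc([N+](=O)[O-])cc1)c1ccccc12` was tested in an ADME assay on L02 cells (Homo sapiens) for antiproliferative activity, read by MTT assay, with a stated time of 48 h; a lower number here means a stronger inhibitor, a higher number a weaker inhibitor. In this assay compound 2 reaches only the limit of > 50000 nM, so no number is known for it. Compound 1 `N#CC1=C(N)Oc2c(N)cc3nc4ccccc4nc3c2C12C(=O)N(Cc1cnnn1-c1ccc(F)cc1)c1ccccc12` carries a fluoro where compound 2 carries a nitro. In this assay compound 1 likewise stops at the limit of > 50000 nM. The step that the two limits leave unreadable from compound 1 to compound 2 therefore cannot be read, because the limit of > 50000 nM in this assay, at which 2 of the 2 values shown sit, holds both values shown. Compound 3 `CCc1cccc(CC)c1-n1nncc1CN1C(=O)C2(C(C#N)=C(N)Oc3c(N)cc4nc5ccccc5nc4c32)c2ccccc21` has not yet been measured in this assay. It differs from compound 2 in one place: 2,6-diethylphenyl in place of 4-nitrophenyl on an aromatic nitrogen. Within the data shown here, only one measured step exists, it concerns a different exchange on the aryl group, and its size is not readable, so it gives no guide to the direction or size of the change expected in this assay. With both known values sitting at the limit, compound 3 is expected to remain at that limit as well, an expected step that the limit leaves unreadable from compound 2 to compound 3 that would not be resolvable. The estimate for compound 3 in this assay is 60000 nM, with a range from 20000 nM to 200000 nM.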

Compound 3, half-maximal inhibitory concentration: > 50000 nM
Compound 3 was reported as a limit (the forecaster's own chance of this, stated with the estimate: 80%); the middle value is on the limit's open side.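

Compound 3 also gives only a limit in this assay, so the steps reaching it from compound 1 and compound 2 cannot be read, because all three compounds stop at the same limit: the limit of > 50000 nM in this assay, at which 3 of the 3 values shown sit.

The compounds shown leave open whether exchanging the aryl group changes the antiproliferative activity at all, and in which direction.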